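Notes on a shared-core series: isobutyl to cyclohexyl

The source may hold more compounds than are shown below. What is called first, only, known or untested is meant among the compounds shown, and "the series" means these compounds.

Measured so far:
compound 1 `Cc1ccc(-c2noc(C3CCc4c(nnn4C(C)(C)C)C3)n2)cn1` — 67%
compound 2 `CC(C)Cc1noc(C2CCc3c(nnn3C(C)(C)C)C2)n1` — 66%

In a functional assay on U2OS cells with metabotropic glutamate receptor 5 (Homo sapiens) as the target, read by calcium flux (a higher number here means a larger maximal response, a lower number a smaller maximal response), compound 1 gives 67% and compound 2 gives 66%. Among the measured compounds shown here, the two numbers lie within the scatter of each other; compound 2 is simply the second of two close values, with compound 1 as its only neighbour. For the measured compounds named here, the one measured step is a number 1 percentage points lower from compound 1 to compound 2 (within the scatter), so the swap of 6-methylpyridin-3-yl for isobutyl on the aromatic carbon left the maximal response unchanged for practical purposes.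

Compound 3 `CC(C)(C)n1nnc2c1CCC(c1nc(C3CCCCC3)no1)C2` is next. It differs from compound 2 in one place: cyclohexyl in place of isobutyl on an aromatic carbon

Going by the values given here, the only step that bears on this is the one from compound 1 to compound 2, which changed the group on the same aromatic carbon and stayed within the scatter. Among the compounds with values here, nothing measured so far shows the read-out moving with what sits at this carbon, and cyclohexyl itself has no precedent. The expectation is therefore no step beyond the scatter. Compound 3 is expected to give 63% in this assay, in the range 45% to 80%. The expected step is a number 3 percentage points lower from compound 2 to compound 3 (within the scatter).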

Compound 3, largest response reached (reported as percent of maximum), in percent of the reference or control that the assay uses: 91%
Compound 3: the middle estimate sits 28 percentage points below what was measured; the measured number lies above the stated range.
By their numbers in this assay, from the lowest: compounds 2 and 1 (each within the scatter of the next); then compound 3.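

At the aromatic carbon between two ring nitrogen atoms, the group can move the maximal response in this assay: cyclohexyl in place of isobutyl gives (a number 25 percentage points higher from compound 2 to compound 3 (beyond the scatter)), and cyclohexyl in place of 6-methylpyridin-3-yl gives (a number 24 percentage points higher from compound 1 to compound 3 (beyond the scatter)). The earlier pair gave no sign of this, and it also shows that a ring at this carbon does not by itself go with the higher number: compound 1 carries a ring and compound 2 none, yet the two lie within the scatter of each other, and only the six-membered non-aromatic ring of carbon only in compound 3 stands apart from both. Nothing at hand bears on why cyclohexyl separates from the other two groups.

Among the compounds shown, it remains open whether the higher response belongs to cyclohexyl alone or extends to other saturated rings, which cyclopentyl, cycloheptyl or piperidine at this carbon would help to settle. Phenyl would test whether an aromatic six-membered ring of carbon only groups with cyclohexyl or with 6-methylpyridin-3-yl.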